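The source may report more compounds than this note shows. Statements on the series, on what has been measured and on what is new or still open speak of the compounds shown alone.

Measured so far:
compound 1 `CC[C@H](C)[C@H](N)CN(C(=O)[C@@H]1C[C@H]1c1ccccc1Cl)c1ccc(-c2ccccc2)cc1` – > 25000 nM
compound 2 `CC[C@H](C)[C@H](N)CN(C(=O)[C@@H]1C[C@H]1c1ccc(C#N)cc1)c1ccc(-c2ccccc2)cc1` – > 25000 nM

In a functional assay for agonist activity at G protein-coupled receptor 88 (Homo sapiens), read by HTRF and cAMP accumulation (a higher number here means that more compound is needed for the effect, a lower number that less compound is needed), compound 1 gives only a limit, > 25000 nM. Compound 2 in this assay likewise gives only a limit, > 25000 nM. Compound 2 thus stands at the limit, and the step that the two limits leave unreadable from compound 1 to compound 2 cannot be read, since (the limit of > 25000 nM in this assay, at which 2 of the 2 values shown sit). Compound 3 `CC[C@H](C)[C@H](N)CN(C(=O)[C@@H]1C[C@H]1c1cccc(C#N)c1)c1ccc(-c2ccccc2)cc1` differs from compound 2 by 3-cyanophenyl in place of 4-cyanophenyl on a saturated ring carbon. For the measured compounds named here, no measured step reads on this change; the only step available, a step that the two limits leave unreadable from compound 1 to compound 2, is itself unreadable. Compound 3 is expected to stay near the limit, with a step that the limit leaves unreadable from compound 2 to compound 3 as the expected step. The estimate for compound 3 in this assay is 30000 nM, range 8000 nM to 100000 nM.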

Compound 3, half-maximal effective concentration: 1600 nM
For compound 3 the middle estimate is 19-fold (1.27 log units) above the measured one; measured number outside the range, below it.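

The 3-cyanophenyl gives the first readable result of the series in this assay, with an at least 15-fold lower number from compound 2 to compound 3 (1.19 log units; beyond the scatter). Against the 2-chlorophenyl the picture is the same, with an at least 15-fold lower number from compound 1 to compound 3 (1.19 log units; beyond the scatter). This carbon of the three-membered ring therefore responds to how the same atoms are joined in its aryl group, while the step from compound 1 to compound 2 still cannot be read: the limit of > 25000 nM in this assay, at which 2 of the 3 values shown sit.

Open, on these data alone, is whether the nitrile itself is needed, or whether 3-chlorophenyl or 3-methoxyphenyl would serve as well. Also open, as far as these compounds go, is how 2-cyanophenyl would compare.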